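The compounds below may be only part of what the source reports. "The series", "measured", "known", "first", "only" and "open" are said of these compounds alone.

Measured compounds:
- Compound 2 `CCn1c(-c2ccc(OCc3c(-c4c(Cl)cccc4Cl)noc3C(C)C)cc2)nc2ccc(C(=O)O)cc21`: 5760 nM
- Compound 1 `CC(C)c1onc(-c2c(Cl)cccc2Cl)c1COc1ccc(-c2nc3ccc(C(=O)O)cc3n2CC2CCCCC2)c(F)c1`: 840 nM

In an assay on HEK-293T cells for antagonist activity at vitamin D3 receptor (Homo sapiens), read by a luciferase reporter, with a stated time of 24 h (a lower number here means a stronger inhibitor, a higher number a weaker inhibitor), compound 2 gives 5760 nM, the highest of the two numbers. Compound 1 gives 840 nM in this assay, a number well apart from that of compound 2. Compound 3 `CC(C)Cn1c(-c2ccc(OCc3c(-c4c(Cl)cccc4Cl)noc3C(C)C)cc2)nc2ccc(C(=O)O)cc21` differs from compound 2 by isopropyl in place of methyl on a saturated chain carbon bound to an aromatic nitrogen. For the measured compounds named here, no pair of measured compounds isolates this change, so its direction is uncertain; a modest move toward a lower number is considered plausible, though none beyond the scatter would not surprise. The expected step is a 2.1-fold lower number from compound 2 to compound 3 (0.31 log units; beyond the scatter). Compound 3 is estimated at 2800 nM. For compound 3 the expected range runs from 1000 nM to 7000 nM.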

Compound 3, half-maximal inhibitory concentration: 1180 nM
The estimate for compound 3 lay 2.4-fold (0.38 log units) above the measured number; the measured number falls inside the stated range.
By their numbers in this assay, from the lowest: compounds 1 and 3 (each within the scatter of the next); then compound 2.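

In this assay, isopropyl in place of methyl on a saturated chain carbon bound to an aromatic nitrogen gives a 4.9-fold lower number from compound 2 to compound 3 (0.69 log units; beyond the scatter), so the number responds to a change at this position. For the compounds shown here, the earlier compounds included no pair that isolated this change, and this is the first step beyond the scatter to be read here. Nothing available offers an explanation for the step. From the compounds shown here alone, whether a longer straight chain or a chain ending in an amine would move the number further in the same direction remains open, since a single step sets no trend.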